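A few compounds are considered here, and "the series" means these few. Any claim that something is new, unique, unknown or untested is made for them only; others in the source may bear on it.

Measured compounds in a functional assay on HL-60 cells (Homo sapiens) for cytotoxicity, read by MTT assay, with a stated time of 4 days; a lower number here means a stronger inhibitor, a higher number a weaker inhibitor:
Compound 1 `C=C1C[C@]23C[C@@]1(O)CC[C@H]2c1cc(Br)c(O)c(C)c1[C@@H]3Cn1cc(-c2ccc(Cl)cc2)nn1` gives 5590 nM.
Compound 2 `C=C1C[C@]23C[C@@]1(O)CC[C@@H]2c1cccc(C)c1[C@@H]3Cn1cc(-c2ccc(F)cc2)nn1` gives > 20000 nM, which is a limit of the assay and not a number.
Compound 3 `Cc1c(O)ccc2c1[C@H](Cn1cc(-c3ccc(Cl)cc3)nn1)[C@@]13CC(=O)[C@@](C)(CC[C@@H]21)C3` gives > 20000 nM, likewise a limit and not a number.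

Compound 2 stands at the limit of > 20000 nM in this assay, at which 2 of the 3 values shown sit; no number is available for it in this assay. Among the compounds with values here, only compound 1 yields a numerical value, and no two measured compounds differ in a single place, so no measured step size exists within the set.

Compound 4 `C=C1C[C@]23C[C@@]1(O)CC[C@@H]2c1cccc(C)c1[C@@H]3Cn1cc(-c2ccccn2)nn1` is the next compound for this assay. It differs from compound 2 by pyridin-2-yl in place of 4-fluorophenyl on an aromatic carbon. Compound 2 itself is only known as a limit, so the starting point of the step is a floor rather than a value. Within the data shown here, with no measured step to draw on, the expectation for the step from compound 2 to compound 4 is none beyond the usual scatter, and the estimated shift a number no higher from compound 2 to compound 4 (the limit leaves the size open) reflects that, in either direction. Compound 4 is therefore expected to give about 20000 nM in this assay, with an estimated range from 8000 nM to 50000 nM, and a fair chance that the assay again returns only a limit.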

Compound 4, half-maximal inhibitory concentration: > 20000 nM
Compound 4 was reported as a limit; the forecaster's own chance of this, stated with the estimate: 60%; the middle value lies on the limit itself.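

In this assay compound 4 gives > 20000 nM, which is a limit of the assay and not a number. Compound 2 is likewise known only as a limit, so no step can be read between compound 2 and compound 4. The compounds shown leave open whether pyridin-2-yl in place of 4-fluorophenyl changes the read-out at all.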